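The compounds below may be only part of what the source reports. "The series", "measured", "known", "first", "only" and "open" are said of these compounds alone.

Measured so far in an assay for inhibition of histone-lysine N-methyltransferase EZH2 variant Y641N (Homo sapiens), read by scintillation counting, with a stated time of 60 min, in the presence of a further agent that is not named here; on this read-out lower numbers stand for stronger inhibition and higher numbers for weaker inhibition:
compound 1 `Cc1cc(C)c(CN2CCc3c(Cl)cc([C@H](CO)[C@@H]4CCCO4)c(Cl)c3C2=O)c(=O)[nH]1` gives 10 nM
compound 2 `Cc1cc(C)c(CN2CCc3c(Cl)cc([C@@H](CO)[C@@H]4CCOC4)c(Cl)c3C2=O)c(=O)[nH]1` gives 1260 nM

Within the data shown here, of these two, compound 2 stands at the higher, weaker end: the only step connecting them, a 130-fold higher number from compound 1 to compound 2 (2.10 log units; beyond the scatter), shows how much ground is lost when the oxolan-2-yl of compound 1 gives way to the oxolan-3-yl of compound 2.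

Compound 3 `Cc1cc(C)c(CN2CCc3c(Cl)cc([C@@H](CO)[C@H]4CCCO4)c(Cl)c3C2=O)c(=O)[nH]1` has not yet been tested. Relative to compound 2 the change is oxolan-2-yl in place of oxolan-3-yl on a saturated chain carbon bound to an aromatic carbon and a saturated chain carbon. Among the measured compounds shown here, that is the reverse of the single measured step, although compound 3 does not simply recreate compound 1, since the arrangement about that chain carbon is not the same. Only a 130-fold higher number from compound 1 to compound 2 (2.10 log units; beyond the scatter) bears on the prediction, and it was a large move. Returning the ring to the oxolan-2-yl attachment is therefore expected to bring the number well down, though how far the changed arrangement at the chain carbon will temper this is unknown from the present data. The expected step is a 13-fold lower number from compound 2 to compound 3 (1.10 log units; beyond the scatter), and compound 3 is estimated to give 100 nM in this assay, within a range of 15 nM to 800 nM.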

Compound 3, inhibition constant: 110 nM
Beside the measured number, compound 3's estimate is 1.1-fold (0.04 log units) below it; low and high end bracket the measured number.
By their numbers in this assay, from the lowest: compound 1; then compound 3; then compound 2.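

Returning to oxolan-2-yl on this saturated chain carbon recovers much of the lost ground in this assay, with an 11-fold lower number from compound 2 to compound 3 (1.06 log units; beyond the scatter), so where the ring is attached still matters strongly when the arrangement at the chain carbon is the one found in compound 3. The attachment alone does not restore the number of compound 1, however, as there remains an 11-fold higher number from compound 1 to compound 3 (1.04 log units; beyond the scatter). This remaining gap adds something the first two compounds could not show, namely that the three-dimensional arrangement of the same atoms counts for about as much as the attachment point, and it can be put down to configuration alone because of this: the fact that compounds 1 and 3 differ only in the configuration as drawn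

From the compounds shown here alone, both stereocentres are inverted together between compound 1 and compound 3, so the shares of the chain carbon and the ring carbon in that gap remain open, and a compound with only one of them inverted would be needed to separate them. Also open, going by these compounds, is how this position responds to other groups, such as a six-membered oxan-2-yl ring in place of oxolan-2-yl, or an amine in place of the hydroxyl of the side chain.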